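A few compounds are considered here, and "the series" means these few. Any claim that something is new, unique, unknown or untested is made for them only; others in the source may bear on it.

Compound 1 `CS(=O)(=O)Nc1ccc(CNC(=O)c2ccc(C34CC(C3)C4)cc2)c(Cl)c1` was tested in an ADME assay on microsomes from liver (Rattus norvegicus, strain Sprague-Dawley) for metabolic stability, read by HPLC, using NADPH, with stated times of 5 min and 60 min, tested at 10 uM (on this read-out higher numbers stand for fast clearance and lower numbers for slow clearance), and gives 17 mL.min-1.g-1, the highest of the three numbers here, though the gaps to the others lie within the usual scatter. Compound 2 `CS(=O)(=O)Nc1ccc(CNC(=O)c2ccc(C(F)(F)F)cc2)c(Cl)c1` gives 9.6 mL.min-1.g-1 in this assay, and compound 3 `CC(C)Oc1ccc(C(=O)NCc2ccc(NS(C)(=O)=O)cc2Cl)cc1` gives 12 mL.min-1.g-1. Both measured steps swapped the same group on the same aromatic carbon: a 1.8-fold lower number from compound 1 to compound 2 (0.25 log units; within the scatter) and a 1.4-fold lower number from compound 1 to compound 3 (0.15 log units; within the scatter). Compound 4 `CS(=O)(=O)Nc1ccc(CNC(=O)c2ccc(C3(O)COC3)cc2)c(Cl)c1` carries a group of 5 heavy atoms (3 carbon, 2 oxygen; one four-membered non-aromatic ring with 1 hetero atom) in place of a group of 5 heavy atoms (5 carbon; 2 four-membered non-aromatic rings of carbon only), on an aromatic carbon. The incoming group brings a hydrogen-bond donor and two acceptors, which neither measured replacement did, so the measured steps bear on it only loosely. The step from compound 1 to compound 4 in this assay is therefore expected to stay within the scatter, a 1.5-fold lower number from compound 1 to compound 4 (0.19 log units; within the scatter). Compound 4 is estimated at 11 mL.min-1.g-1, in a range from 5 mL.min-1.g-1 to 22 mL.min-1.g-1.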

Compound 4, intrinsic clearance in microsomes: 5.4 mL.min-1.g-1
For compound 4 the middle estimate is 2.0-fold (0.31 log units) above the measured one, within the range that was stated.
By their numbers in this assay, from the lowest: compounds 4, 2, 3 and 1 (each within the scatter of the next, the first and the last beyond it).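

For the compounds shown here, on this aromatic carbon, para to a large group, 3-hydroxyoxetan-3-yl gives the first steps in this assay that lie beyond the scatter: a 3.1-fold lower number from compound 1 to compound 4 (0.50 log units; beyond the scatter), and a 2.2-fold lower number from compound 3 to compound 4 (0.35 log units; beyond the scatter). Against trifluoromethyl the new group shows no clear separation, with a 1.8-fold lower number from compound 2 to compound 4 (0.25 log units; within the scatter). No measurement here accounts for these steps. Still open, on these data alone, is whether the hydroxyl or the oxetane ring matters more, which an oxetan-3-yl group without the hydroxyl could test. A primary amine at this position also remains an open case.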